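This account rests on a few compounds, and the source may have more. Where it says the series, first, only, none or still open, it means among the compounds named here.

Measured in a physicochemical assay for lipophilicity; on this read-out lower numbers stand for lower lipophilicity and higher numbers for higher lipophilicity:
compound 1 `CN(C)C1CC(C)(C)NC(C)(C)C1`: 2.89
compound 2 `NCC(=O)CN`: 1.43
compound 3 `OCCNC1CCN(Cc2ccccc2)CC1`: 2.57

Compound 1 stands highest of these three in this assay, and the values of compound 3 and compound 2 both lie lower by more than the usual scatter. Compound 4 `CC1(C)CC(NCCO)CC(C)(C)N1` has (2-hydroxyethyl)amino in place of dimethylamino on a saturated ring carbon. Among the measured compounds shown here, no measured pair isolates this change, so any expectation rests on thin evidence. Compound 3 carries the same (2-hydroxyethyl)amino group on a different core and reads 2.57, which gives only a loose guide. A clear downward move, beyond the scatter, is expected, and the estimated step is a number 0.99 log units lower from compound 1 to compound 4 (beyond the scatter). Compound 4 is expected at 1.9, with an estimated range from 1.3 to 2.5.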

Compound 4, partition coefficient: 3.1
Beside the measured number, compound 4's estimate is 1.20 log units below it; measured number above the stated range.
By their numbers in this assay, from the lowest: compound 2; then compound 3; then compounds 1 and 4 (each within the scatter of the next).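

Among the compounds shown here, on the saturated ring carbon of the core of compound 1, (2-hydroxyethyl)amino in place of dimethylamino gives, in this assay, a number 0.21 log units higher from compound 1 to compound 4 (within the scatter) as the first measured pair to isolate this change. The entering group brings an oxygen and hydrogen-bond donors that dimethylamino lacks, yet compound 1 and compound 4 stay within the scatter of each other. Nothing measured here accounts for this result. As far as these compounds go, whether a longer chain ending in hydroxyl, or a carboxylic acid, would read the same at this ring carbon remains open. So does whether the same exchange would give a similar step on another core.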